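A few compounds are considered here, and "the series" means these few. Any claim that something is new, unique, unknown or untested is made for them only; others in the source may bear on it.

Measured compounds in a functional assay on HL-60 cells (Homo sapiens) for antiproliferative activity, with a stated time of 24 h; on this read-out lower numbers stand for stronger inhibition and higher numbers for weaker inhibition:
compound 1, `NC(=O)c1c(NC(=O)c2ccccc2Cl)sc2c1CCN(Cc1c(Cl)cccc1Cl)C2`, in this assay compound 1 gives 4850 nM
compound 2, `NC(=O)c1c(NC(=O)c2ccccc2Cl)sc2c1CCN(C(=S)Nc1cccc3ccccc13)C2`, in this assay compound 2 gives 13400 nM

Compound 2 holds the higher of the two numbers in this assay. The nearest value is that of compound 1, which sits lower by a gap that lies beyond the usual scatter of repeat measurements. Among the compounds with values here, the two compounds share a core and differ in the group carried on the ring nitrogen of that core; this is not a single counted change, and no step between them is worked out here.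

Compound 3, `NC(=O)c1c(NC(=O)c2ccccc2Cl)sc2c1CCN(C(=S)Nc1ccccc1F)C2`, keeps the thiocarbonyl-bearing nitrogen of compound 2 and alters only the aryl group attached to it: 2-fluorophenyl in place of naphthalen-1-yl on an amide-type nitrogen. The change leaves the count of donors, acceptors and charge untouched. Within the data shown here, no measured pair shows this change, so its size in this assay is not known from the data. The expectation is a step of small size, in either direction or none beyond the scatter, since nothing measured points one way. Compound 3 is estimated at 10000 nM, with a range from 3500 nM to 30000 nM, which means an expected step of a 1.3-fold lower number from compound 2 to compound 3 (0.13 log units; within the scatter).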

Compound 3, half-maximal inhibitory concentration: 4970 nM
Compound 3: middle estimate off by 2.0-fold (0.30 log units), on the high side; low and high end bracket the measured number.
By their numbers in this assay, from the lowest: compounds 1 and 3 (each within the scatter of the next); then compound 2.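

In this assay, within the data shown here, the aryl group on the amide-type nitrogen proves able to move the number: 2-fluorophenyl in place of naphthalen-1-yl gives the first single-place step (a 2.7-fold lower number from compound 2 to compound 3 (0.43 log units; beyond the scatter)), with one six-membered aromatic ring in place of two. On the amine nitrogen in a ring of the shared core, the group of compound 3 and the group of compound 1 cannot be told apart on this read-out (a 1.0-fold higher number from compound 1 to compound 3 (0.01 log units; within the scatter)), so the thiocarbonyl-bearing group is not set apart from the group of compound 1 once it carries 2-fluorophenyl. Nothing at hand bears on why the aryl change shifts the number.

This one pair does not separate the loss of the second aromatic ring from the entry of fluorine, and plain phenyl on the same nitrogen would be the group to divide the two. Also open, on these data alone, is how a saturated ring such as cyclohexyl, or a chain such as n-butyl, would read in place of the aryl group in this assay.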